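Adding a Chloro Group to the Trifluoromethyl Benzylamide

The compounds below may be only part of what the source reports. "The series", "measured", "known", "first", "only" and "open" are said of these compounds alone.

Compound 3 `CCN1C(=O)CC[C@H]1C(=O)NCc1cccc(C(F)(F)F)c1` gives 100 nM in an assay on isolated protein for inhibition of P2X purinoceptor 7 (Homo sapiens) (a higher number here means a weaker inhibitor, a lower number a stronger inhibitor), the lowest of the two numbers shown. Compound 1 `CCN1C(=O)CC[C@H]1C(=O)NCc1ccccc1Cl`, which carries a chloro group on its aromatic ring, gives 631 nM in this assay, a step beyond the usual scatter. For compound 2 `CCN1C(=O)CC[C@H]1C(=O)NCc1cccc(Cl)c1` this assay reports only a limit, < 1000 nM, and no number.

The next compound, compound 4 `CCN1C(=O)CC[C@H]1C(=O)NCc1cccc(C(F)(F)F)c1Cl`, differs from compound 3 by chloro in place of hydrogen on an aromatic carbon. Among the compounds with values here, the only measured step that touches the same ring, a step that the limit leaves unreadable from compound 2 to compound 3, cannot be read in size, because the limit of < 1000 nM in this assay, at which 1 of the 3 values shown sits, hides it. No measured step places a chloro group on a ring that already bears a trifluoromethyl group, so the change has no direct precedent among these compounds. Compound 1 shows that a chloro-bearing ring can still give a number in the range seen for compound 3, but the two structures differ in more than one place.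

With no readable step to lean on, compound 4 is expected to stay near compound 3, with the added chloro group judged unlikely to shift the number beyond the scatter in either direction. The step from compound 3 to compound 4 is therefore estimated as a 1.3-fold lower number from compound 3 to compound 4 (0.10 log units; within the scatter). Compound 4 is estimated at 80 nM, with a range from 25 nM to 300 nM.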

Compound 4, half-maximal inhibitory concentration: 1.59 nM
Compound 4: the middle estimate sits 50-fold (1.70 log units) above what was measured; measured number outside the range, below it.
By their numbers in this assay, from the lowest: compound 4; then compound 3; then compound 1.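

In this assay, chloro on an aromatic carbon, ortho to a trifluoromethyl group, turns out to be far from a neutral addition, giving a 63-fold lower number from compound 3 to compound 4 (1.80 log units; beyond the scatter). Compound 4 can also be read the other way round, with trifluoromethyl in place of hydrogen on the chloro-bearing ring of compound 1, and that change is just as clearly large, giving a 400-fold lower number from compound 1 to compound 4 (2.60 log units; beyond the scatter). Within the data shown here, each of the two groups thus gives a large step when the other is already on the ring, which no earlier readable step could show, while the step that starts from compound 2 still cannot be read: the limit of < 1000 nM in this assay, at which 1 of the 4 values shown sits.

The compounds shown leave open whether this large step belongs to chloro itself or would also appear with another group at the same place, such as fluoro, bromo, methyl or a nitrile. They also leave open whether the step would hold if the ethyl group on the shared core gave way to a longer chain or a cyclopropyl group.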